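A few compounds are considered here, and "the series" means these few. Any claim that something is new, unique, unknown or untested is made for them only; others in the source may bear on it.

Compound 2, `CCc1cc(NCc2ccc(-c3ccccc3-c3nn[nH]n3)cc2)c(Cl)c(CC)n1`, sits second highest among the three numbers available for a functional assay on the whole organism for inhibition, with Rattus norvegicus as the target; a lower number here means that less compound is needed, a higher number that more compound is needed for the effect. Its nearest neighbour is compound 1, `Cc1cc(NCc2ccc(-c3ccccc3-c3nn[nH]n3)cc2)c(I)c(C)n1`, which in this assay gives 0.05 mg/kg, a reading within the scatter of the value for compound 2 of 0.06 mg/kg. Furthest away is compound 3, `CCc1cc(OCc2ccc(-c3ccccc3-c3nn[nH]n3)cc2)c(I)c(CC)n1`, which in this assay gives 0.44 mg/kg, a gap beyond the scatter. The unmeasured compound 4, `CCc1cc(NCc2ccc(-c3ccccc3-c3nn[nH]n3)cc2)c(I)c(CC)n1`, departs from compound 2 by a single change: iodo in place of chloro on an aromatic carbon.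

Going by the values given here, no measured pair isolates that swap. Compound 1 already carries iodo together with the same linker as compound 2 and compound 4, and its number in this assay lies within the scatter of compound 2; the larger difference to compound 3 comes with a different linker. On that basis compound 4 is expected to show no step beyond the scatter, with no change at the digits printed from compound 2 to compound 4 (within the scatter) as the anticipated change. Compound 4 is therefore estimated at 0.06 mg/kg, within a range from 0.025 mg/kg to 0.15 mg/kg.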

Compound 4, dose for half-maximal effect: 0.13 mg/kg
Compound 4: the middle estimate sits 2.2-fold (0.34 log units) below what was measured; low and high end bracket the measured number.
By their numbers in this assay, from the lowest: compounds 1 and 2 (each within the scatter of the next); then compound 4; then compound 3.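

In this assay, going by these compounds alone, the halogen at this position, ortho to an ethyl group and two atoms from the ring nitrogen, is seen on its own for the first time: iodo in place of chloro gives a 2.2-fold higher number from compound 2 to compound 4 (0.34 log units; beyond the scatter) with the rest of the structure unchanged, a modest step but one beyond the scatter. Compound 4 also gives compound 3 a partner that differs from it only in the linker, and with iodo and both ethyl groups kept, compound 3 gives 0.44 mg/kg against compound 4 at 0.13 mg/kg in this assay.

Going by these compounds, with only chloro and iodo compared here, it remains open how bromo, fluoro or a nitrile at this carbon would read. The data shown offer nothing that accounts for the step from chloro to iodo.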